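Swapping Fluoro for Chloro on the Amide-Bound Ring

This account rests on a few compounds, and the source may have more. Where it says the series, first, only, none or still open, it means among the compounds named here.

Compound 1, `CC1=C(C(=O)Nc2ccc(Cl)c(Cl)c2)C(c2cccc(O)c2)NC(=S)N1`, gives 15800 nM in a functional assay on NCI/ADR-RES cells (Homo sapiens) for cytotoxicity, read by sulforhodamine B assay, with a stated time of 48 h; a lower number here means a stronger inhibitor of growth, a higher number a weaker inhibitor of growth.
Compound 2, `CC1=C(C(=O)Nc2ccc(F)c(Cl)c2)C(c2cccc(Cl)c2)NC(=S)N1`, gives 15800 nM.
Compound 3, `CC1=C(C(=O)Nc2ccc(F)c(Cl)c2)C(c2cccc(Oc3ccccc3)c2)NC(=S)N1`, gives 15500 nM.

All three numbers in this assay sit within the scatter of one another, so compound 3 cannot be set apart from compound 1 or compound 2 on these values. Compound 4, `CC1=C(C(=O)Nc2ccc(Cl)c(Cl)c2)C(c2cccc(Oc3ccccc3)c2)NC(=S)N1`, differs from compound 3 by chloro in place of fluoro on an aromatic carbon. Among the compounds with values here, no measured pair isolates this change. Within the data shown here, the only single-point step, a 1.0-fold lower number from compound 2 to compound 3 (0.01 log units; within the scatter), concerns a different position and was flat. Compound 1, which already carries the 3,4-dichlorophenyl group, and compound 3 give values within the scatter of each other. Compound 4 is therefore expected to show no change at the digits printed from compound 3 to compound 4 (within the scatter), with an estimated value of 15500 nM, ranging from 7000 nM to 34000 nM.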

Compound 4, concentration for 50% growth inhibition: 15500 nM
Estimate against measurement, compound 4: no gap at the digits printed, within the range that was stated.
By their numbers in this assay, from the lowest: compounds 3, 4, 1 and 2 (each within the scatter of the next).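

In this assay, within the data shown here, chloro in place of fluoro on the ring bound to the amide gives no change at the digits printed from compound 3 to compound 4 (within the scatter), the first direct reading of this change at this position. With the 3,4-dichlorophenyl group in place, phenyl in place of hydrogen on an oxygen on an aromatic ring gives a 1.0-fold lower number from compound 1 to compound 4 (0.01 log units; within the scatter), so this change is also flat on that background. Nothing available explains these flat results. Going by these compounds, it remains open whether an amine or a carboxylic acid on the ring bound to the amide would shift the number. The same applies to a longer chain in place of the phenoxy group.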